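Swapping a halogen for a nitro group on the aryl tail

This account rests on a few compounds, and the source may have more. Where it says the series, first, only, none or still open, it means among the compounds named here.

Four compounds share one core, a nucleotide triphosphate carrying a side chain that ends in an aromatic ring, and differ only in that ring. In a functional assay on 1321-N1 cells for agonist activity at P2Y purinoceptor 2 (Homo sapiens), read by scintillation counting and inositol phosphate accumulation (a lower number here means that less compound is needed, a higher number that more compound is needed for the effect), compound 1 `O=c1[nH]/c(=N\OCCCCc2ccccc2)ccn1[C@@H]1O[C@H](COP(=O)(O)OP(=O)(O)OP(=O)(O)O)[C@@H](O)[C@H]1O` gives 214 nM. Compound 2 `O=c1[nH]/c(=N\OCCCc2ccc(Br)cc2)ccn1[C@@H]1O[C@H](COP(=O)(O)OP(=O)(O)OP(=O)(O)O)[C@@H](O)[C@H]1O` gives 350 nM in this assay, and compound 3 `O=c1[nH]/c(=N\OCCCc2cccc(I)c2)ccn1[C@@H]1O[C@H](COP(=O)(O)OP(=O)(O)OP(=O)(O)O)[C@@H](O)[C@H]1O` gives 325 nM. Compound 2 has the highest number of the three, yet both of its neighbours sit within the scatter: a 1.6-fold higher number from compound 1 to compound 2 (0.21 log units; within the scatter), a 1.1-fold lower number from compound 2 to compound 3 (0.03 log units; within the scatter), and also a 1.5-fold higher number from compound 1 to compound 3 (0.18 log units; within the scatter). So far, then, changing the aromatic tail has not shifted the result beyond what repeated measurements would show on their own.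

Compound 4 `O=c1[nH]/c(=N\OCCCc2ccc([N+](=O)[O-])cc2)ccn1[C@@H]1O[C@H](COP(=O)(O)OP(=O)(O)OP(=O)(O)O)[C@@H](O)[C@H]1O` is not yet measured. It differs from compound 2 by nitro in place of bromo on an aromatic carbon. All three measured steps bear on this change, since each alters only the substituent pattern of the same ring, and each was within the scatter. Absent any measured step for a nitro group, no larger effect can be inferred, and the expectation in this assay is a step from compound 2 to compound 4 that stays inside the scatter: no change at the digits printed from compound 2 to compound 4 (within the scatter). Compound 4 is therefore estimated at 350 nM, with a range from 150 nM to 800 nM.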

Compound 4, half-maximal effective concentration: 458 nM
The estimate for compound 4 lay 1.3-fold (0.12 log units) below the measured number; the range from low to high includes it.
By their numbers in this assay, from the lowest: compounds 1, 3, 2 and 4 (each within the scatter of the next, the first and the last beyond it).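

In this assay, nitro brings 3 heavy atoms and 2 hydrogen-bond acceptors to a place where bromo had 1 heavy atom and no acceptors, yet the swap on this aromatic carbon, para to a large group, stays within the scatter: a 1.3-fold higher number from compound 2 to compound 4 (0.12 log units; within the scatter). The comparison with the iodo tail reads the same way, with a 1.4-fold higher number from compound 3 to compound 4 (0.15 log units; within the scatter), so neither halogen-bearing tail can be told apart from the nitro tail in these measurements. The one step here that passes the scatter, and the first among these tails, is the modest 2.1-fold higher number from compound 1 to compound 4 (0.33 log units; beyond the scatter), and nothing measured alongside these numbers accounts for it.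

The compounds shown leave open whether an amine or a carboxylic acid on the same aromatic carbon would also stay within the scatter of compound 2. They also leave open what a nitro group would do on another carbon of the ring, so these few tails show no general rule for the ring as a whole.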